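Butyl in Place of Methoxy: What Dose to Expect

The source may hold more compounds than are shown below. What is called first, only, known or untested is meant among the compounds shown, and "the series" means these compounds.

Of the compounds shown here, three have been tested in a functional assay on the whole organism (strain Sprague-Dawley) for inhibition, with Rattus norvegicus as the target; on this read-out higher numbers stand for an effect only at larger amounts of compound and lower numbers for an effect already at smaller amounts. Compound 1, `CCc1ccc2c(=O)c(-c3nn[nH]n3)c[nH]c2c1`, gave only a limit of the assay, > 10 mg/kg. Compound 2, `COc1cccc2cc(C(=O)O)cnc12`, gave a number, 150 mg/kg. Compound 3, `COc1ccc2ncc(-c3nn[nH]n3)cc2c1`, also gave only a limit, > 25 mg/kg, so its true dose is not known as a number; it sits at the limit of > 25 mg/kg in this assay, at which 1 of the 3 values shown sits, and no comparison between compound 3 and the others can be drawn beyond that. Compound 4, `CCCCc1ccc2ncc(-c3nn[nH]n3)cc2c1`, has not yet been tested in this assay. It differs from compound 3 in one place: butyl in place of methoxy on an aromatic carbon. Within the data shown here, no pair of compounds measured so far shows what this kind of change does in this assay, so the size and direction of the step cannot be read from the data. Given that compound 3 reached only a limit, compound 4 is expected to require a dose near 50 mg/kg, with the range 20 mg/kg to 200 mg/kg, and the step expected is a step that the limit leaves unreadable from compound 3 to compound 4, which may well fall within the scatter or again end as a limit rather than a number.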

Compound 4, minimum effective dose: > 25 mg/kg
Compound 4 ended at the assay's limit (the forecaster's own chance of this, stated with the estimate: 60%); the middle value lies beyond the limit too.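

In this assay, compound 3 and compound 4 both ended at a limit of the assay rather than at a number, so the step between them cannot be read. The compounds shown leave open whether butyl in place of methoxy on an aromatic carbon changes the dose required at all, and in which direction.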